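This account rests on a few compounds, and the source may have more. Where it says the series, first, only, none or still open, it means among the compounds named here.

For the measured compounds named here, compound 1 `O=C(O)c1cc(-c2cccc(COc3ccc4c(c3)CN(C3CCCC3)C4=O)c2)ccc1O` is one of three compounds measured in an ADME assay on microsomes from liver (Rattus norvegicus) for metabolic stability, read by LC-MS, with a stated time of 1 h, at 37 degrees C, tested at 4 uM (on this read-out higher numbers stand for a more stable compound and lower numbers for a less stable compound), and in that assay compound 1 gives 9%. That is the lowest of the three numbers. Compound 2 `Cn1sc2cc(OCc3cccc(-c4ccc(Cl)c(C(=O)O)c4)c3)ccc2c1=O` gives 84% in this assay, a result beyond the usual scatter above compound 1, and compound 3 `CN(C)C(=O)c1cc(-c2cccc(COc3ccc4c(=O)n(C5CCCC5)sc4c3)c2)ccc1Cl` gives 92%, the furthest from compound 1 and also beyond the scatter. Going by the values given here, compounds 2 and 3 carry a different core from compound 1, so none of the three pairs differs in a single place and no direct step is available.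

Compound 4 `O=C(O)c1ccc(Cl)c(-c2cccc(COc3ccc4c(c3)CN(C3CCCC3)C4=O)c2)c1` keeps the core of compound 1 and changes only the aryl group: 5-carboxy-2-chlorophenyl in place of 3-carboxy-4-hydroxyphenyl on an aromatic carbon. Compound 2 carries the same 5-carboxy-2-chlorophenyl group on its own core and reaches 84%, while compound 1 with 3-carboxy-4-hydroxyphenyl sits far lower; whether the core or the aryl group drives the gap cannot be told from these compounds. Compound 4 is therefore expected to show an estimated step of a number 36 percentage points higher from compound 1 to compound 4 (beyond the scatter), an expected rise whose size is uncertain. Compound 4 is estimated at 45%, in a range from 15% to 80%.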

Compound 4, percent of the compound remaining: 15%
Beside the measured number, compound 4's estimate is 30 percentage points above it; low and high end bracket the measured number.
By their numbers in this assay, from the lowest: compounds 1 and 4 (each within the scatter of the next); then compounds 2 and 3 (each within the scatter of the next).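

Putting 5-carboxy-2-chlorophenyl in place of 3-carboxy-4-hydroxyphenyl on an aromatic carbon gives a number 6 percentage points higher from compound 1 to compound 4 (within the scatter) in this assay, so on the core of compound 1 the two aryl groups cannot be told apart by this read-out. For the compounds shown here, this is the first reading at this position with the core held fixed, something the earlier compounds could not give, as none of their pairs differed in a single place. No measurement at hand bears on the reason for this result.

As far as these compounds go, it remains open whether a group lacking the carboxylic acid, such as an aminophenyl or a pyridine ring, would read differently on this aromatic carbon of the core of compound 1. How much the core itself contributes also stays open, as the compounds shown offer no pair that differs in the core alone.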